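A few compounds are considered here, and "the series" means these few. Any claim that something is new, unique, unknown or untested is made for them only; others in the source may bear on it.

Compound 2, `Cc1c(NCC(C)C)c(=O)n(-c2ccccc2)c(=O)n1C`, sits alongside compound 1, `CCCNc1c(C)n(C)c(=O)n(-c2ccccc2)c1=O`, on a shared core. In a physicochemical assay for lipophilicity (a higher number here means a more lipophilic compound, a lower number a more polar compound), compound 1 gives 1.2, and compound 2 gives 1.48. Going by the values given here, the one measured step, a number 0.28 log units higher from compound 1 to compound 2 (within the scatter), lies within the usual scatter of this kind of measurement, so the two numbers cannot be told apart with any confidence.

Compound 3, `CCN(CC)c1c(C)n(C)c(=O)n(-c2ccccc2)c1=O`, is the next compound to be measured in this assay. It differs from compound 2 in one place: diethylamino in place of isobutylamino on an aromatic carbon. Among the compounds with values here, no measured step matches this kind of change; the single step from compound 1 to compound 2 added a methyl group to a saturated chain, whereas here the same atoms are joined differently and one hydrogen-bond donor is lost. Without a matching step, only a loose expectation is possible. Compound 3 is expected at 1.7, within a range from 1.3 to 2.1. That estimate means a step of a number 0.22 log units higher from compound 2 to compound 3 (within the scatter), which is expected to be no larger than the usual scatter.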

Compound 3, partition coefficient: 2.11
Estimate against measurement, compound 3: 0.41 log units below; measured number above the stated range.
By their numbers in this assay, from the lowest: compounds 1 and 2 (each within the scatter of the next); then compound 3.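

At this position on the shared core, the way the atoms of the side chain are joined matters in this assay, not only which atoms are present: isobutylamino and diethylamino hold the same atoms, yet the swap gives a number 0.63 log units higher from compound 2 to compound 3 (beyond the scatter) and so stands clear of the scatter, which the earlier added methyl group did not. Going by these compounds alone, the same holds against the shorter chain, with a number 0.91 log units higher from compound 1 to compound 3 (beyond the scatter) and a size that puts compound 3 apart from both earlier compounds, so diethylamino in place of either amine with a chain on its nitrogen is the first change here that can be read with confidence. No measurement shown explains why this rise occurs.

From the compounds shown here alone, what stays open is whether the step follows the loss of the hydrogen-bond donor, since diethylamino has 0 where isobutylamino has 1, or the different shape of the chains, as these two changes arrive together in this swap. Going by these compounds, a ring amine such as piperidine, or a longer chain on the same nitrogen, would help separate the two, and whether the swap moves the number as far on a different core also remains unknown.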